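A few compounds are considered here, and "the series" means these few. Any claim that something is new, unique, unknown or untested is made for them only; others in the source may bear on it.

Of the compounds shown here, two built on one shared core have been measured in a physicochemical assay for solubility, read by HPLC, in phosphate buffer, with a stated time of 24 h, at pH 7.4; a higher number here means a more soluble compound, a lower number a less soluble compound. Compound 1 `COc1ccc(Cn2nnc(O)c2C(=O)Nc2cccc(C(F)(F)F)c2)cc1`, which carries a trifluoromethyl group on an aromatic carbon, gives 21200 nM. Compound 2 `COc1ccc(Cn2nnc(O)c2C(=O)Nc2cccc(-c3cccc(O)c3)c2)cc1`, with 3-hydroxyphenyl in place of that trifluoromethyl, gives 40300 nM. Among the compounds with values here, the one measured step, a 1.9-fold higher number from compound 1 to compound 2 (0.28 log units; within the scatter), lies within the scatter, so compound 2 stands level with compound 1 on these numbers.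

Compound 3 `COc1ccc(Cn2nnc(O)c2C(=O)Nc2cccc(-c3ccc(OC)cc3)c2)cc1` keeps the core and has 4-methoxyphenyl in place of 3-hydroxyphenyl on an aromatic carbon, meta to a large group: 4-methoxyphenyl in place of 3-hydroxyphenyl on an aromatic carbon. Within the data shown here, no measured pair shows this exchange directly. Among the measured compounds shown here, the only guide is the step from compound 1 to compound 2, a different exchange at the same place, whose two values stay within the scatter of each other. One step is thin evidence, but on that basis no step beyond the scatter is expected in this assay, in either direction. The estimated step, a 1.6-fold lower number from compound 2 to compound 3 (0.21 log units; within the scatter), stays within that scatter. For compound 3 the expected solubility is 25000 nM, with an estimated range of 8000 nM to 60000 nM.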

Compound 3, solubility: < 1000 nM
Compound 3: a limit, no number; the forecaster's own chance of this, stated with the estimate: 5%; middle value at least 25-fold (1.39 log units) from the limit.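

The result shows that this place on the core is not indifferent to what it carries in this assay: 4-methoxyphenyl brings an at least 40-fold lower number from compound 2 to compound 3 (1.60 log units; beyond the scatter), and the same group brings an at least 21-fold lower number from compound 1 to compound 3 (1.32 log units; beyond the scatter). Compound 3 gives < 1000 nM, which is a limit of the assay and not a number, so both steps are minimum sizes: the limit of < 1000 nM in this assay, at which 1 of the 3 values shown sits A six-membered aromatic ring of carbon only at this place does not by itself set the reading, since compound 2 and compound 3 both carry such a ring and still lie far apart.

The exchange from 3-hydroxyphenyl to 4-methoxyphenyl changes more than one thing at once: the name of the group shows a different substituent at a different ring position, and the count of hydrogen-bond donors goes from 1 to 0, so the compounds shown cannot say which of these differences matters. As far as these compounds go, it also stays open how 3-methoxyphenyl or 4-hydroxyphenyl would read, and whether an aromatic ring bearing an amine or a carboxylic acid would stand nearer to compound 2 or to compound 3.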